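The compounds below may be only part of what the source reports. "The series", "measured", "known", "first", "only" and "open" are said of these compounds alone.

In a functional assay on HCT-15 cells (Homo sapiens) for cytotoxicity, read by sulforhodamine B assay, with a stated time of 72 h (a lower number here means a stronger inhibitor of growth, a higher number a weaker inhibitor of growth), compound 1 `CC(=O)N1c2ccccc2CCC1C(=O)Nc1ccccc1O` gives 54500 nM while compound 2 `O=C(Nc1ccccc1O)C1CCc2ccccc2N1C(=O)c1ccccc1Cl` gives 44900 nM and compound 3 `O=C(Nc1ccccc1O)C1CCc2ccccc2N1C(=O)c1ccc(Cl)cc1` gives 20200 nM as the lowest of the three numbers. The modest steps are a 2.7-fold lower number from compound 1 to compound 3 (0.43 log units; beyond the scatter) and a 2.2-fold lower number from compound 2 to compound 3 (0.35 log units; beyond the scatter) while a 1.2-fold lower number from compound 1 to compound 2 (0.08 log units; within the scatter) stays within the scatter. Compound 4 `O=C(Nc1ccccc1C(F)(F)F)C1CCc2ccccc2N1C(=O)c1ccc(Cl)cc1` keeps the 4-chlorophenyl group of compound 3 and carries trifluoromethyl in place of hydroxy on an aromatic carbon in a spot ortho to a large group. Going by the values given here, none of the measured steps touches that spot. All three change only the group on the carbonyl carbon, so they hint at how large a single change in this series can be but give no direction for this one. In this assay, among the compounds with values here, no step clearly beyond the scatter is therefore expected, though a larger move in either direction remains possible. The expected change is a 1.3-fold lower number from compound 3 to compound 4 (0.13 log units; within the scatter) and it is only a cautious guess. For compound 4 the estimate is 15000 nM (expected range 4000 nM to 50000 nM).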

Compound 4, concentration for 50% growth inhibition: 839 nM
Beside the measured number, compound 4's estimate is 18-fold (1.25 log units) above it; the measured number lies below the stated range.
By their numbers in this assay, from the lowest: compound 4; then compound 3; then compounds 2 and 1 (each within the scatter of the next).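

In this assay, going from 2-hydroxyphenyl to 2-(trifluoromethyl)phenyl gives a 24-fold lower number from compound 3 to compound 4 (1.38 log units; beyond the scatter), so this position matters more than the group on the carbonyl carbon did across compound 1, compound 2 and compound 3. Hydroxy, with its hydrogen-bond donor and acceptor, is therefore not required for growth inhibition in this pair, as trifluoromethyl has neither and gives the lower number. No measurement here explains why the number falls so far.

Two things change at once, the loss of hydroxy and the arrival of trifluoromethyl, and the compounds shown cannot separate them, whereas a plain hydrogen, a methyl or a chlorine at this spot could. As far as these compounds go, it also remains open whether the same gain holds with methyl or 2-chlorophenyl on the carbonyl carbon.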